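Hydroxy to amino on an aromatic carbon

The source may report more compounds than this note shows. Statements on the series, on what has been measured and on what is new or still open speak of the compounds shown alone.

Compound 1 `C/C(=N\NC(=S)N1CCOCC1)c1ccccc1` gives 44600 nM in a functional assay on MCF7 cells (Homo sapiens) for antiproliferative activity, read by MTT assay, with a stated time of 72 h (a higher number here means a weaker inhibitor, a lower number a stronger inhibitor), and serves as the reference point for this short series. Compound 2 `C/C(=N\NC(=S)N1CCOCC1)c1ccccc1O` carries a hydroxy group in place of a hydrogen on an aromatic carbon and gives 49200 nM in this assay as well, so it stands level with compound 1 within the usual scatter. Compound 3 `C/C(=N\NC(=S)N1CCOCC1)c1ccccc1N` is still unmeasured and has amino in place of hydroxy on that aromatic carbon, ortho to a large group (amino in place of hydroxy on an aromatic carbon). Among the measured compounds shown here, only one measured step bears on this change, and it involves the same position (a 1.1-fold higher number from compound 1 to compound 2 (0.04 log units; within the scatter)). With so little evidence, no shift beyond the scatter is expected in this assay. The estimated step is therefore small (a 1.2-fold lower number from compound 2 to compound 3 (0.09 log units; within the scatter)). Compound 3 is expected to give 40000 nM (estimated range 18000 nM to 85000 nM).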

Compound 3, half-maximal inhibitory concentration: > 64000 nM
Compound 3: no number, only a limit (the forecaster's own chance of this, stated with the estimate: 10%); middle value at least 1.6-fold (0.20 log units) from the limit.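

In this assay compound 3 gives only a limit of the assay, not a number: the limit of > 64000 nM in this assay, at which 1 of the 3 values shown sits.

Read against that limit, the steps are floors rather than full sizes: an at least 1.3-fold higher number from compound 2 to compound 3 (0.11 log units; that floor lies within the scatter), and an at least 1.4-fold higher number from compound 1 to compound 3 (0.15 log units; that floor lies within the scatter). Amino on this aromatic carbon, ortho to a large group, therefore shows no gain in strength over hydroxy or hydrogen, which is more than the earlier pair could say about this position, but whether it truly differs from either group cannot be read.

Going by these compounds, what a methoxy group or a chlorine atom on this aromatic carbon would give stays open. So does whether any group in this place can bring the number well down from where compound 1 stands.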